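The source may hold more compounds than are shown below. What is called first, only, known or untested is meant among the compounds shown, and "the series" means these compounds.

Values measured in a functional assay on DU-145 cells (Homo sapiens) for inhibition, read by trypan blue exclusion, with a stated time of 72 h; on this read-out higher numbers stand for weaker inhibition and lower numbers for stronger inhibition:

- compound 1 `Cn1c(=O)c(S(=O)(=O)Cc2ccc(F)cc2F)cc2cnc(Nc3ccc4[nH]ccc4c3)nc21` gives 1000 nM
- compound 2 `Cn1c(=O)c(S(=O)(=O)c2ccc(F)cc2)cc2cnc(Nc3ccc4[nH]ccc4c3)nc21` gives 300 nM

Of these two compounds, compound 2 holds the lower number, and thus the stronger inhibition, at 300 nM. Compound 3 `Cc1ccc(S(=O)(=O)c2cc3cnc(Nc4ccc5[nH]ccc5c4)nc3n(C)c2=O)cc1` keeps everything in compound 2 except one substituent: methyl in place of fluoro on an aromatic carbon, para to a large group. Going by the values given here, only one measured step bears on this change, and only indirectly: a 3.3-fold lower number from compound 1 to compound 2 (0.52 log units; beyond the scatter). That modest step exchanged the whole 2,4-difluorobenzyl for 4-fluorophenyl on a sulfonyl sulfur, whereas the new change swaps one heavy atom for one heavy atom. Among the compounds with values here, no measured step tests this swap directly, so no shift beyond the scatter is expected in this assay, and no direction can be favoured with confidence. The expected step is a 1.1-fold higher number from compound 2 to compound 3 (0.04 log units; within the scatter). For compound 3 the estimated value is 330 nM, with an expected range of 120 nM to 900 nM.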

Compound 3, half-maximal inhibitory concentration: 750 nM
Beside the measured number, compound 3's estimate is 2.3-fold (0.36 log units) below it; measured number inside the range.
By their numbers in this assay, from the lowest: compound 2; then compounds 3 and 1 (each within the scatter of the next).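

In this assay, the position para to a large group proves sensitive to a swap of one heavy atom for one heavy atom: methyl in place of fluoro gives a modest shift (a 2.5-fold higher number from compound 2 to compound 3 (0.40 log units; beyond the scatter)). Set against 2,4-difluorobenzyl on the sulfonyl sulfur, 4-methylphenyl cannot be told apart (a 1.3-fold lower number from compound 1 to compound 3 (0.12 log units; within the scatter)), which leaves 4-fluorophenyl as the only one of the three groups with a number clearly lower than the other two. No evidence is available to account for the shift.

Only fluoro and methyl are shown at this position, so it remains open how chloro, methoxy or an amine there would compare with compound 2. Also unknown is whether the unsubstituted phenyl would fall closer to compound 2 or to compound 3.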